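The source may hold more compounds than are shown below. What is called first, only, known or untested is meant among the compounds shown, and "the series" means these compounds.

Compounds measured in a functional assay (Cavia porcellus) with sulfonylurea receptors; K-ATP channels (Homo sapiens) as the target; a lower number here means a stronger inhibitor, a higher number a weaker inhibitor:
compound 1 `CC(O)(C(=O)Nc1ccc(S(=O)(=O)c2ccccc2F)cc1)C(F)(F)F` gives 1300 nM
compound 2 `COc1cccc(S(=O)(=O)c2ccc(NC(=O)C(C)(O)C(F)(F)F)cc2)c1` gives 16000 nM
compound 3 `Cc1ccc(S(=O)(=O)c2ccc(NC(=O)C(C)(O)C(F)(F)F)cc2)cc1` gives > 30000 nM

For compound 3 this value is a limit of the assay and not a number; the compound sits at the limit of > 30000 nM in this assay, at which 1 of the 3 values shown sits. It is reached from compound 1 by an at least 23-fold higher number from compound 1 to compound 3 (1.36 log units; beyond the scatter), and from compound 2 by an at least 1.8-fold higher number from compound 2 to compound 3 (0.27 log units; that floor lies within the scatter). Compound 1, the lowest value shown, is separated from compound 2 by a 12-fold higher number from compound 1 to compound 2 (1.09 log units; beyond the scatter).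

Compound 4 `CN(c1ccccc1)S(=O)(=O)c1ccc(NC(=O)C(C)(O)C(F)(F)F)cc1` differs from compound 3 in one place: methyl(phenyl)amino in place of 4-methylphenyl on a sulfonyl sulfur. For the measured compounds named here, all three measured steps exchange one aryl group for another on the sulfonyl sulfur; none exchanges a carbon attachment for a nitrogen attachment, so no measured step bears directly on this change. Compound 3 itself is known only as a limit, so the size of the step is uncertain. Compound 4 is therefore expected to remain a weak inhibitor, with the step of a number no higher from compound 3 to compound 4 (the limit leaves the size open) not placed beyond the scatter with confidence. The estimate for compound 4 in this assay is 30000 nM, within a range of 6000 nM to 100000 nM.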

Compound 4, half-maximal inhibitory concentration: 2000 nM
Compound 4: middle estimate off by 15-fold (1.18 log units), on the high side; the measured number lies below the stated range.
By their numbers in this assay, from the lowest: compounds 1 and 4 (each within the scatter of the next); then compound 2. At a limit, above all of these: compound 3.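

In this assay, for the compounds shown here, a nitrogen attachment on the sulfonyl sulfur, something no earlier aryl-for-aryl step could speak to, proves compatible with inhibition: methyl(phenyl)amino gives an at least 15-fold lower number from compound 3 to compound 4 (1.17 log units; beyond the scatter) and an 8.0-fold lower number from compound 2 to compound 4 (0.90 log units; beyond the scatter). Set against 2-fluorophenyl, the same group gives a 1.5-fold higher number from compound 1 to compound 4 (0.19 log units; within the scatter), so two quite different groups on this sulfur share a range apart from 3-methoxyphenyl and 4-methylphenyl. The value of compound 3 is a limit and not a number, so the first of these steps gives only a floor for the change: the limit of > 30000 nM in this assay, at which 1 of the 4 values shown sits.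

The compounds shown leave open whether the nitrogen attachment, the methyl on it or the phenyl on it accounts for this result. They also leave open how an amine with hydrogen in place of that methyl, or a longer chain on that nitrogen, would behave at this position.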